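A Pyridin-2-yl Group on the Amide-Type Nitrogen

The source may hold more compounds than are shown below. What is called first, only, known or untested is meant among the compounds shown, and "the series" means these compounds.

In a functional assay on A549 cells (Homo sapiens) for inhibition, read by MTT assay, with a stated time of 72 h (on this read-out lower numbers stand for stronger inhibition and higher numbers for weaker inhibition), compound 1 (`CCCc1ccc(NC(=O)C2CCN(C/C=C/c3ccccc3)CC2)cc1`) gives 9470 nM while compound 2 (`CC(C)c1ccc(NC(=O)C2CCN(C/C=C/c3ccccc3)CC2)cc1`) gives 9430 nM and compound 3 (`O=C(Nc1cccc(Br)c1)C1CCN(C/C=C/c2ccccc2)CC1`) gives 16500 nM and thus stands within the scatter of both others. Compound 4 (`O=C(Nc1ccccn1)C1CCN(C/C=C/c2ccccc2)CC1`) carries pyridin-2-yl in place of 3-bromophenyl on an amide-type nitrogen. For the measured compounds named here, two measured steps concern that place, a 1.7-fold higher number from compound 1 to compound 3 (0.24 log units; within the scatter) and a 1.7-fold higher number from compound 2 to compound 3 (0.24 log units; within the scatter) and both lie within the scatter. Going by the values given here, no measured compound carries a ring with a hetero atom there. On those two steps, no change beyond the scatter is expected in this assay for this swap. The expected outcome is a 1.1-fold higher number from compound 3 to compound 4 (0.04 log units; within the scatter) as an estimate. Compound 4 is expected at 18000 nM with 8000 nM to 45000 nM as the estimated range.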

Compound 4, half-maximal inhibitory concentration: 89300 nM
Beside the measured number, compound 4's estimate is 5.0-fold (0.70 log units) below it; measured number above the stated range.
By their numbers in this assay, from the lowest: compounds 2, 1 and 3 (each within the scatter of the next); then compound 4.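

In this assay, for the compounds shown here, pyridin-2-yl is the first group at the amide-type nitrogen to move the number beyond the scatter (a 5.4-fold higher number from compound 3 to compound 4 (0.73 log units; beyond the scatter); a 9.5-fold higher number from compound 2 to compound 4 (0.98 log units; beyond the scatter); a 9.4-fold higher number from compound 1 to compound 4 (0.97 log units; beyond the scatter)). The position therefore does respond to change, although the three groups with carbon-only rings gave no step beyond the scatter, and the weaker number comes with the ring holding a hetero atom. Nothing measured here accounts for this step. Going by these compounds, it remains open whether plain phenyl would sit with compound 3 or with compound 4, which would separate the ring nitrogen from the lost ring substituent. On these data alone, whether pyridin-3-yl would behave like pyridin-2-yl also remains open.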